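Benzyl removal on the aryl ether: acid versus ester

This account rests on a few compounds, and the source may have more. Where it says the series, first, only, none or still open, it means among the compounds named here.

Four compounds share a biaryl-thiophene scaffold and differ at an oxygen on an aromatic ring and at the carboxyl end. Compound 1 `COc1ccc(-c2sc(C(=O)O)cc2-c2cc(OC)c(OC)c(OC)c2)cc1OCc1ccccc1` carries a benzyl on that oxygen. In a functional assay on HT-1080 cells (Homo sapiens) for antiproliferative activity, read by MTT assay, with a stated time of 72 h (a higher number here means a weaker inhibitor, a lower number a stronger inhibitor), compound 1 reaches only the limit of the assay, > 100000 nM. Compound 2 `COc1ccc(-c2sc(C(=O)O)cc2-c2cc(OC)c(OC)c(OC)c2)cc1O` carries hydrogen in its place, and in this assay compound 2 gives 7510 nM. The change hydrogen in place of benzyl on an oxygen on an aromatic ring produces an at least 13-fold lower number from compound 1 to compound 2 (1.12 log units; beyond the scatter); the step is stated only as a bound because of the limit of > 100000 nM in this assay, at which 2 of the 3 values shown sit.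

Compound 3 `CCOC(=O)c1cc(-c2ccc(OC)c(OCc3ccccc3)c2)c(-c2cc(OC)c(OC)c(OC)c2)s1` has the same benzyl on the same oxygen but a different core; the difference between the core of compound 1 and the core of compound 3 is not broken down here. In this assay compound 3 also sits at the limit, > 100000 nM. Compound 4 `CCOC(=O)c1cc(-c2ccc(OC)c(O)c2)c(-c2cc(OC)c(OC)c(OC)c2)s1` is compound 3 with the same change, (hydrogen in place of benzyl on an oxygen on an aromatic ring), made at the same place as in the measured pair.

Going by the values given here, with one measured example of this change, and that one a bound, the expected step for compound 4 is an at least 16-fold lower number from compound 3 to compound 4 (1.22 log units; beyond the scatter), resting on the single step of an at least 13-fold lower number from compound 1 to compound 2 (1.12 log units; beyond the scatter). Compound 4 is therefore estimated at 6000 nM, expected to fall between 1000 nM and 60000 nM, with a real chance that the assay again reports only its limit.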

Compound 4, half-maximal inhibitory concentration: 82600 nM
Compound 4: the middle estimate sits 14-fold (1.14 log units) below what was measured; measured number above the stated range.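

In this assay, benzyloxy to hydroxy on the core of compound 3 gives an at least 1.2-fold lower number from compound 3 to compound 4 (0.08 log units; that floor lies within the scatter), and this figure is a floor and not a measured size. In both pairs the hydroxy compound returns a number where the benzyloxy compound returns only a limit, which is as far as the carry-over from one core to the other can be read, and the two steps cannot be said to match in size or to differ: the same change on two cores in this assay, an at least 13-fold lower number (1.12 log units; beyond the scatter) from compound 1 to compound 2 and an at least 1.2-fold lower number (0.08 log units; that floor lies within the scatter) from compound 3 to compound 4; the limit leaves it open whether they differ. The true size of neither step is known, and the data do not show whether the core or the carboxyl end alters what the change does, as both benzyl compounds give no number to start from: the limit of > 100000 nM in this assay, at which 2 of the 4 values shown sit.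

The compounds shown leave open what a step would look like on either core from a starting compound that gives a number, for instance one with an ethyl or a longer chain on that oxygen in place of benzyl. They also leave open whether an amine in place of the hydroxy would give a number on these cores, and how the carboxylic acid and the ethyl ester compare on a single shared core.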